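The compounds below may be only part of what the source reports. "The series", "measured", "known", "first", "only" and "open" are said of these compounds alone.

Among the measured compounds shown here, in an ADME assay on BaF3 cells (Mus musculus) for antiproliferative activity (on this read-out lower numbers stand for stronger inhibition of growth and higher numbers for weaker inhibition of growth), only two compounds have been read so far. Compound 1 (`Cc1ccc(NC(=O)c2cccc(C(F)(F)F)c2)cc1OC1CCN(C(=O)c2ccccn2)CC1`) carries a pyridin-2-yl on its carbonyl carbon, and its result of > 10000 nM is a limit, not a number. Compound 2 (`Cc1ccc(NC(=O)c2cccc(C(F)(F)F)c2)cc1OC1CCN(C(=O)c2ccno2)CC1`) carries a 1,2-oxazol-5-yl there, and its result of > 10000 nM is also a limit. Compound 2 therefore has no measured potency, and it stands with compound 1 at the limit of > 10000 nM in this assay, at which 2 of the 2 values shown sit. For the measured compounds named here, the only measured step is a step that the two limits leave unreadable from compound 1 to compound 2. It has no readable size and lies at another place in the molecule, so it gives no guide to size or direction.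

Compound 3 (`Cc1ccc(NC(=O)c2ccc(C)c(C(F)(F)F)c2)cc1OC1CCN(C(=O)c2ccno2)CC1`) differs from compound 2 by methyl in place of hydrogen on an aromatic carbon, ortho to a trifluoromethyl group. No shift beyond the usual scatter can be forecast from these data, and weak inhibition of growth is expected to persist, given compound 2 at > 10000 nM. The expected change is a number no higher from compound 2 to compound 3 (the limit leaves the size open). The estimate for compound 3 is 10000 nM, with an expected range from 3000 nM to 30000 nM, and the assay may well report only a limit again.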

Compound 3, concentration for 50% growth inhibition: 8940 nM
Beside the measured number, compound 3's estimate is 1.1-fold (0.05 log units) above it; the range from low to high includes it.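

In this assay, methyl in place of hydrogen on an aromatic carbon, ortho to a trifluoromethyl group, gives an at least 1.1-fold lower number from compound 2 to compound 3 (0.04 log units; that floor lies within the scatter), so this change can be read only as a floor that does not go beyond the usual scatter. Among the compounds shown here, it does show that a compound with this methyl group can give a number rather than a limit, as compound 3 gives 8940 nM, and this is the first step in the set with any readable size. The two earlier results remain limits and not numbers, so compound 3 has only a limit to stand against: the limit of > 10000 nM in this assay, at which 2 of the 3 values shown sit.

The compounds shown leave open the true size of this step, and whether the same methyl group would also bring a number with the pyridin-2-yl on the carbonyl carbon of compound 1. They also leave open how a chlorine, a methoxy group or an amine would read at this position on the six-membered aromatic ring, so a single methyl step supports no pattern.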